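The source may report more compounds than this note shows. Statements on the series, on what has been measured and on what is new or still open speak of the compounds shown alone.

Among the measured compounds shown here, compound 2 `COc1cccc(N(C)CC(=O)N2CCC[C@H](c3ccccc3)[C@@H]2CN2CCCC2)c1` is the weaker of the two compounds measured so far: in an assay on HEK293 cells for displacement of a labelled ligand from Urotensin-2 receptor (Homo sapiens) (a higher number here means a weaker inhibitor, a lower number a stronger inhibitor), compound 2 gives 794 nM, the highest of the two numbers, and its nearest neighbour is compound 1 `CN(CC(=O)N1CCC[C@H](c2ccccc2)[C@@H]1CN1CCCC1)c1ccc2ccccc2c1`, for which compound 1 gives 158 nM. For the measured compounds named here, the one measured step between them, a 5.0-fold higher number from compound 1 to compound 2 (0.70 log units; beyond the scatter), shows that exchanging the group on the amine nitrogen of the shared core shifts the read-out by a modest amount.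

The next compound, compound 3 `CN(CC(=O)N1CCC[C@H](c2ccccc2)[C@@H]1CN1CCCC1)Cc1ccc(Cl)c(Cl)c1`, differs from compound 2 in that same place: 3,4-dichlorobenzyl in place of 3-methoxyphenyl on an amine nitrogen. Going by the values given here, no measured step covers a benzyl group on that nitrogen, nor a chlorine-bearing ring, so the step from compound 1 to compound 2 bears on it only indirectly, as a sign of how much that position can move the number. The estimate for compound 3 therefore rests on the two measured values and is expected to fall somewhere between them, with the step of a 2.6-fold lower number from compound 2 to compound 3 (0.42 log units; beyond the scatter) from compound 2 taken as a moderate, uncertain gain rather than a confident one, and with a wide range: compound 3 is estimated at 300 nM, expected between 60 nM and 1500 nM.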

Compound 3, inhibition constant: 3980 nM
The estimate for compound 3 lay 13-fold (1.12 log units) below the measured number; measured number above the stated range.
By their numbers in this assay, from the lowest: compound 1; then compound 2; then compound 3.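

The exchange on the amine nitrogen can raise the number as well as lower it: a 5.0-fold higher number from compound 2 to compound 3 (0.70 log units; beyond the scatter) in this assay is the same size as the earlier step between the two aryl groups, and it runs further in the same direction. With 3,4-dichlorobenzyl in this place, the span at this one position widens to a 25-fold higher number from compound 1 to compound 3 (1.40 log units; beyond the scatter), so the three groups on the nitrogen now separate clearly, with naphthalen-2-yl giving the lowest number, 3-methoxyphenyl the middle one and 3,4-dichlorobenzyl the highest. No available evidence bears on why the number rises with this change.

The step from 3-methoxyphenyl to 3,4-dichlorobenzyl alters the ring's substituents and its attachment to the nitrogen at once, so the compounds shown cannot assign the rise to either change alone. An unsubstituted benzyl group or a chlorine-bearing phenyl ring attached directly to that nitrogen would separate the two, and the compounds shown say nothing about a ring carrying an amine or a carboxylic acid there.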